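This account rests on a few compounds, and the source may have more. Where it says the series, first, only, none or still open, it means among the compounds named here.

Measured so far:
compound 1 `C/C(=N\NC(=O)COc1cccc2ccccc12)c1ccc([N+](=O)[O-])cc1` — 3.37
compound 2 `O=C(COc1cccc2ccccc12)N/N=C/c1ccccc1Cl` — 4.54
compound 3 `O=C(COc1cccc2ccccc12)N/N=C/c1c[nH]c2ccccc12` — 3.79

In a physicochemical assay for lipophilicity, measured as octanol-water partition (on this read-out higher numbers stand for higher lipophilicity and lower numbers for lower lipophilicity), compound 2 gives 4.54, the highest of the three numbers. Compound 3 is the nearest, a number lower by more than the usual scatter, and compound 1 is the furthest, lower still. Compound 4 `COc1ccc(/C=N/NC(=O)COc2cccc3ccccc23)cc1` is not yet measured. It differs from compound 2 in one place: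

4-methoxyphenyl in place of 2-chlorophenyl on a carbon with a double bond to nitrogen

For the measured compounds named here, no measured pair shows a change of this kind, so the size of the step cannot be read from the data; it is estimated here as a downward move in this assay beyond the scatter. For compound 4 the expected value is 3.8, within a range from 3.4 to 4.3. The expected step is a number 0.74 log units lower from compound 2 to compound 4 (beyond the scatter).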

Compound 4, partition coefficient: 3.77
Compound 4: middle estimate off by 0.03 log units, on the high side; the measured number falls inside the stated range.
By their numbers in this assay, from the lowest: compound 1; then compounds 4 and 3 (each within the scatter of the next); then compound 2.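

In this assay, putting 4-methoxyphenyl in place of 2-chlorophenyl on a carbon with a double bond to nitrogen gives a number 0.77 log units lower from compound 2 to compound 4 (beyond the scatter), so the group at this position alone can move the read-out by more than the scatter. This change swaps a chlorine for an oxygen-bearing group that adds a hydrogen-bond acceptor, and it also alters where the substituent sits on the ring. No measurement here explains the step. Which of these differences matters remains open. An unsubstituted phenyl or a ring carrying an amine would help separate them.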